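The compounds below may be only part of what the source reports. "The series", "measured", "known", "first", "only" and "open" are said of these compounds alone.

Within the data shown here, compound 3, with the structure `Cc1ccc(-c2nnc(N3CCN(C(=O)CN4CCN(c5ccccc5)CC4)CC3)nc2-c2ccc(C)cc2)cc1`, is the one member of this small set that gives a number rather than a limit in a functional assay on MCF7 cells (Homo sapiens) for cytotoxicity, read by MTT assay, with a stated time of 24 h; a higher number here means a weaker inhibitor, a lower number a stronger inhibitor: in this assay compound 3 gives 914000 nM. Compound 1, with the structure `O=C(CN1CCN(c2ccccc2)CC1)N1CCN(c2nnc(-c3ccccc3)c(-c3ccccc3)n2)CC1`, reaches only a limit in this assay, giving > 963000 nM. Compound 2, with the structure `COc1cccc(N2CCN(CC(=O)N3CCN(c4nnc(-c5ccccc5)c(-c5ccccc5)n4)CC3)CC2)c1`, likewise reaches only a limit in this assay, giving > 910000 nM. Among the measured compounds shown here, the step from compound 1 to compound 2, a step that the two limits leave unreadable from compound 1 to compound 2, is therefore the only measured step of the same kind, and its size cannot be read, because the limit of > 910000 nM in this assay, at which 1 of the 3 values shown sits, and the limit of > 963000 nM in this assay, at which 1 of the 3 values shown sits, both mark the top of the range reached.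

Compound 4, with the structure `COc1ccccc1N1CCN(CC(=O)N2CCN(c3nnc(-c4ccc(C)cc4)c(-c4ccc(C)cc4)n3)CC2)CC1`, differs from compound 3 by methoxy in place of hydrogen on an aromatic carbon. No readable step bears on this change, and compound 3 itself sits close to the limits of compounds 1 and 2. The step expected in this assay, a 1.0-fold lower number from compound 3 to compound 4 (0.01 log units; within the scatter), is accordingly not expected to go beyond the scatter in either direction. Compound 4 is estimated at 900000 nM, in the range from 400000 nM to 2000000 nM.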

Compound 4, half-maximal inhibitory concentration: 59400 nM
Estimate against measurement, compound 4: 15-fold (1.18 log units) above, and the stated range ends above it.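

In this assay, among these compounds, methoxy in place of hydrogen gives a 15-fold lower number from compound 3 to compound 4 (1.19 log units; beyond the scatter), the first readable step for this change and one that lies beyond the scatter. It shows that, at this place on an aromatic carbon ortho to a large group, the change from phenyl to 2-methoxyphenyl can move the number a long way, whereas the earlier step of the same kind, between compound 1 and compound 2, cannot be read, as both of its ends are limits. No measured property among the compounds shown accounts for the size of this step. The compounds shown leave open whether the step belongs to methoxy itself or would also come with hydroxyl, fluorine or an amine at the same place. They also leave open whether 2-methoxyphenyl would give a readable step on the core of compound 1.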